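This account rests on a few compounds, and the source may have more. Where it says the series, first, only, none or still open, it means among the compounds named here.

Measured so far in a functional assay on TK-10 cells (Homo sapiens) for inhibition, read by sulforhodamine B assay, with a stated time of 48 h; on this read-out lower numbers stand for stronger inhibition of growth and higher numbers for weaker inhibition of growth:
compound 1 `COc1ccc(-c2cc(/C=C/C(=O)c3ccc(N)cc3)[nH]n2)cc1` gives 2810 nM
compound 2 `COc1ccc(-c2cc(/C=C/C(=O)c3ccc(N)cc3)[nH]n2)cc1OC` gives 1090 nM
compound 3 `COc1cc(C(=O)/C=C/c2cc(-c3cc(OC)c(OC)c(OC)c3)n[nH]2)cc(OC)c1OC` gives 1460 nM

Compound 2 and compound 1 differ in one place, (hydrogen in place of methoxy on an aromatic carbon), and this change gives a 2.6-fold higher number from compound 2 to compound 1 (0.41 log units; beyond the scatter). Compound 3 stands between the two: its gap to compound 2 and its gap to compound 1 both lie within the scatter, so no order among these three can be claimed from those pairs. How the core of compound 3 differs from that of compound 2 is not broken down here.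

Compound 4 `COc1ccc(-c2cc(/C=C/C(=O)c3cc(OC)c(OC)c(OC)c3)[nH]n2)cc1OC` is not yet measured. It differs from compound 3 by hydrogen in place of methoxy on an aromatic carbon. This is the same kind of change as that from compound 2 to compound 1, though not the same: in compound 3 the place is also meta to a methoxy group, which is not so in compound 2.

For the measured compounds named here, compound 4 is expected to show a step of a 2.5-fold higher number from compound 3 to compound 4 (0.39 log units; beyond the scatter) in this assay, resting on the single earlier step of a 2.6-fold higher number from compound 2 to compound 1 (0.41 log units; beyond the scatter) and on the value of compound 3, 1460 nM. Going by the values given here, with only one prior instance of this kind of change, the range is kept wide. The estimate for compound 4 is 3600 nM, between 1500 nM and 8500 nM.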

Compound 4, concentration for 50% growth inhibition: 3270 nM
Beside the measured number, compound 4's estimate is 1.1-fold (0.04 log units) above it; the measured number falls inside the stated range.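

In this assay, hydrogen in place of methoxy on an aromatic carbon gives a 2.2-fold higher number from compound 3 to compound 4 (0.35 log units; beyond the scatter). Set beside the earlier case, the step keeps its direction and its size on the two cores: the same change on two cores in this assay, a 2.6-fold higher number (0.41 log units; beyond the scatter) from compound 2 to compound 1 and a 2.2-fold higher number (0.35 log units; beyond the scatter) from compound 3 to compound 4, 1.2-fold (0.06 log units) apart, within the scatter of two such steps. For the compounds shown here, this supports carrying the change between these two cores, but it rests on only two pairs, in a single cell line, and in both the ring keeps at least one other methoxy group, so it fixes no rule for other cores and gives no reason for the higher number.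

The compounds shown leave open whether a hydroxy group, a fluorine or a longer chain such as ethoxy at this place would give a number closer to that of methoxy or of hydrogen. Also open, as far as these compounds go, is what happens when every methoxy group on this ring gives way to hydrogen, and whether the step holds with a carboxylic acid on the other aromatic ring.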